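The source may hold more compounds than are shown below. What is called first, only, known or untested is meant among the compounds shown, and "the series" means these compounds.

Measured so far in an ADME assay on LLC-MK2 cells (Macaca mulatta) for cytotoxicity, read by spectrophotometry and crystal violet staining, with a stated time of 4 days; a higher number here means that more compound is tolerated, a lower number that less compound is tolerated:
- compound 1, `CC(C)n1ncc2c(C(=O)Nc3ccc(F)c(S(N)(=O)=O)c3)cc(-c3cccs3)nc21`: 50000 nM
- compound 2, `CC(C)n1ncc2c(C(=O)Nc3cccnc3)cc(-c3cccs3)nc21`: only a limit of this assay, > 200000 nM
- compound 3, `CC(C)n1ncc2c(C(=O)N3CCc4cccnc43)cc(-c3cccs3)nc21`: 50000 nM

Compound 3 stands level with compound 1 at the digits shown, within the scatter. Going by the values given here, the only step measured at the carbonyl carbon is an at least 4.0-fold lower number from compound 2 to compound 3 (0.60 log units; beyond the scatter); one of the three values sits at the limit of > 200000 nM in this assay, at which 1 of the 3 values shown sits.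

Compound 4, `CC(C)n1ncc2c(C(=O)Nc3ccc(F)cc3)cc(-c3cccs3)nc21`, differs from compound 3 by a group of 8 heavy atoms (6 carbon, 1 nitrogen, 1 fluorine; one six-membered aromatic ring of carbon only) in place of a group of 9 heavy atoms (7 carbon, 2 nitrogen; one five-membered non-aromatic ring with 1 hetero atom, one six-membered aromatic ring with 1 hetero atom), on a carbonyl carbon. Among the compounds with values here, no measured step involves the (4-fluorophenyl)amino group itself. The nearest anchor is compound 1 with 50000 nM, which carries a fluorinated anilide at the same carbonyl, so no step beyond the scatter is expected, no change at the digits printed from compound 3 to compound 4 (within the scatter).

Compound 4 is estimated at 50000 nM in this assay, within 20000 nM to 200000 nM.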

Compound 4, half-maximal cytotoxic concentration: > 200000 nM
Compound 4: only a limit was reported; the forecaster's own chance of this, stated with the estimate: 25%; middle value at least 4.0-fold (0.60 log units) away from the limit.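

In this assay, the open anilide tolerates more compound than the fused amide at the carbonyl carbon, with an at least 4.0-fold higher number from compound 3 to compound 4 (0.60 log units; beyond the scatter). The sulfamoyl group also matters on its own, since hydrogen in its place gives an at least 4.0-fold higher number from compound 1 to compound 4 (0.60 log units; beyond the scatter). The step between compound 2 and compound 4 cannot be read, as both values are limits of the assay: the limit of > 200000 nM in this assay, at which 2 of the 4 values shown sit.

As far as these compounds go, how far compound 4 lies past its limit stays open. Also open, from the compounds shown here alone, is whether an amine or a carboxylic acid in place of sulfamoyl on that aromatic carbon would lower the number as sulfamoyl does.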